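3,4-Dihydroxyphenyl in Place of 3,4-Dimethoxyphenyl: Compound 4

The source may report more compounds than this note shows. Statements on the series, on what has been measured and on what is new or still open speak of the compounds shown alone.

Compound 1, `O=[N+]([O-])c1ccc(NC(=S)N2CCN(S(=O)(=O)c3sccc3-c3ccccc3Oc3ccc(O)c(O)c3)CC2)cc1`: in an ADME assay on HEK-293T cells (Homo sapiens) for cytotoxicity, read by CCK-8 assay, with a stated time of 48 h (a lower number here means a stronger inhibitor, a higher number a weaker inhibitor), compound 1 gives > 20000 nM, a limit of the assay.
Compound 2, `COc1ccc(Oc2ccc([N+](=O)[O-])cc2-c2ccsc2S(=O)(=O)N2CCN(C(=O)Nc3ccc([N+](=O)[O-])cc3)CC2)cc1OC`: compound 2 gives > 20000 nM, also a limit.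
Compound 3, `COc1ccc(Oc2ccc(C(C)C)cc2-c2ccsc2S(=O)(=O)NCCNC(=O)Nc2cc(Cl)cc(Cl)c2)cc1OC`: compound 3 gives 11900 nM.

Within the data shown here, compound 3 thus holds the only number; the other two values are limits, as the limit of > 20000 nM in this assay, at which 2 of the 3 values shown sit, records. Compound 4, `CC(C)c1ccc(Oc2ccc(O)c(O)c2)c(-c2ccsc2S(=O)(=O)NCCNC(=O)Nc2cc(Cl)cc(Cl)c2)c1`, differs from compound 3 in one place: 3,4-dihydroxyphenyl in place of 3,4-dimethoxyphenyl on an oxygen on an aromatic ring. Among the measured compounds shown here, no measured pair carries the same change, so its size cannot be read from the data. Compound 1 also carries a 3,4-dihydroxyphenyl group and stands at a limit. In this assay the step is expected to be either within the scatter or a weakening, estimated as a 1.3-fold higher number from compound 3 to compound 4 (0.13 log units; within the scatter). Compound 4 is therefore expected at 16000 nM, between 6000 nM and 40000 nM, with a fair chance that only a limit is reported.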

Compound 4, half-maximal inhibitory concentration: > 10000 nM
Compound 4: only a limit was reported (the forecaster's own chance of this, stated with the estimate: 40%); the middle value lies beyond the limit too.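

In this assay compound 4 gives > 10000 nM, a limit of the assay. Among these compounds, no step from compound 3 to compound 4 can be read. The compounds shown leave open how far 3,4-dihydroxyphenyl in place of 3,4-dimethoxyphenyl shifts the number in this assay.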